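The source may hold more compounds than are shown below. What is called first, only, known or untested is meant among the compounds shown, and "the series" means these compounds.

Working notes on the series. Compound 1 `C[C@@H]1CCCN1c1c(C#N)c2c(N)nc(Nc3cn[nH]c3)nc2n1C` is the reference without a substituent on the ring nitrogen; in an assay on isolated protein for inhibition of Leucine-rich repeat serine/threonine-protein kinase 2 (Homo sapiens), read by TR-FRET and LanthaScreen, with stated times of 50 min and 30 min, in the presence of a further agent that is not named here (on this read-out higher numbers stand for weaker inhibition and lower numbers for stronger inhibition), compound 1 gives 6 nM. Compound 2 `Cc1nn(C2COC2)cc1Nc1nc(N)c2c(C#N)c(N3CCC[C@H]3C)n(C)c2n1` carries the oxetan-3-yl group, and in this assay compound 2 gives 38 nM, the highest of the two single numbers available, separated from compound 1 by the step of a 6.3-fold higher number from compound 1 to compound 2 (0.80 log units; beyond the scatter). Compound 3 `Cc1nn(C2CCOC2)cc1Nc1nc(N)c2c(C#N)c(N3CCC[C@H]3C)n(C)c2n1`, a close analogue of compound 2, has been run more than once: in this assay compound 3 gives 19 nM; 44 nM (2 entries), and the spread of those entries (the several entries of compound 3 in this assay, 19 nM; 44 nM (2 entries)) shows how far repeats of one compound can drift.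

Compound 4 `Cc1nn(CC(C)(C)O)cc1Nc1nc(N)c2c(C#N)c(N3CCC[C@H]3C)n(C)c2n1` is not yet measured. Its change from compound 2 is 2-hydroxy-2-methylpropyl in place of oxetan-3-yl on an aromatic nitrogen. Within the data shown here, no measured step swaps one group for another at this nitrogen; the closest comparison is compound 2 against compound 3, whose values lie within scatter of each other. The step in this assay is therefore expected to be small, given as a 1.3-fold lower number from compound 2 to compound 4 (0.10 log units; within the scatter). Compound 4 is estimated at 30 nM, within 10 nM to 90 nM.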

Compound 4, half-maximal inhibitory concentration: 49 nM
Compound 4: the middle estimate sits 1.6-fold (0.21 log units) below what was measured; low and high end bracket the measured number.
By their numbers in this assay, from the lowest: compound 1; then compounds 2 and 4 (each within the scatter of the next).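

The swap of oxetan-3-yl for 2-hydroxy-2-methylpropyl on this aromatic nitrogen gives, in this assay, a 1.3-fold higher number from compound 2 to compound 4 (0.11 log units; within the scatter), and so does not separate the two compounds. At this position, a four-membered non-aromatic ring can therefore give way to a chain with no ring and a hydrogen-bond donor, which oxetan-3-yl lacks, without a step beyond the scatter. Repeat measurements of a single close analogue in this assay spread more widely than this step: the several entries of compound 3 in this assay, 19 nM; 44 nM (2 entries)

The compounds shown leave open whether an amine or a carboxylic acid on this nitrogen would move the number beyond the scatter. They also do not separate the part played by the methyl group on the pyrazole from that of the nitrogen substituent in a 6.3-fold higher number from compound 1 to compound 2 (0.80 log units; beyond the scatter).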